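Cytotoxicity of Triazole-Linked Analogues: Trimming a Dioxolane Side Chain

This account rests on a few compounds, and the source may have more. Where it says the series, first, only, none or still open, it means among the compounds named here.

Measured so far:
Compound 1, `O=C1c2c[n+]([O-])c3ccccc3c2C(=O)c2c1c1ccccc1n2Cc1cn([C@H]2C[C@H](O)[C@@H](CO)O2)nn1`: in a toxicity assay on L02 cells (Homo sapiens) for cytotoxicity, read by MTT assay, with a stated time of 72 h (on this read-out higher numbers stand for weaker inhibition and lower numbers for stronger inhibition), compound 1 gives 280 nM.
Compound 2, `O=C1c2c[n+]([O-])c3ccccc3c2C(=O)c2c1c1ccccc1n2Cc1cn(C[C@@H](O)CO)nn1`: in this assay compound 2 gives 490 nM.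
Compound 3, `CC1(C)O[C@@H](CO)[C@H](Cn2cc(Cn3c4c(c5ccccc53)C(=O)c3c[n+]([O-])c5ccccc5c3C4=O)nn2)O1`: in this assay compound 3 gives 500 nM.

Compound 3 has the largest of the three numbers shown, yet its separation from either neighbour lies within the scatter: a 1.8-fold higher number from compound 1 to compound 3 (0.25 log units; within the scatter) and a 1.0-fold higher number from compound 2 to compound 3 (0.01 log units; within the scatter). Compound 4, `CC1(C)OCC(Cn2cc(Cn3c4c(c5ccccc53)C(=O)c3c[n+]([O-])c5ccccc5c3C4=O)nn2)O1`, is not yet measured. It differs from compound 3 in one place: 2,2-dimethyl-1,3-dioxolan-4-yl in place of 5-(hydroxymethyl)-2,2-dimethyl-1,3-dioxolan-4-yl on a saturated chain carbon bound to an aromatic nitrogen.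

For the measured compounds named here, no measured step removes the same group, so the bearing steps are indirect. All three changes to the chain on the triazole nitrogen — a 1.8-fold higher number from compound 1 to compound 2 (0.24 log units; within the scatter), a 1.8-fold higher number from compound 1 to compound 3 (0.25 log units; within the scatter), a 1.0-fold higher number from compound 2 to compound 3 (0.01 log units; within the scatter) — stayed within the scatter. The step from compound 3 to compound 4 is therefore expected to be small as well, with no direction beyond the scatter, which means an expected no change at the digits printed from compound 3 to compound 4 (within the scatter). Compound 4 is estimated at 500 nM in this assay, with a range from 250 nM to 1000 nM.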

Compound 4, half-maximal inhibitory concentration: 120 nM
For compound 4 the middle estimate is 4.2-fold (0.62 log units) above the measured one, outside the stated range (below it).
By their numbers in this assay, from the lowest: compound 4; then compounds 1, 2 and 3 (each within the scatter of the next).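

In this assay, for the compounds shown here, the exchange of 5-(hydroxymethyl)-2,2-dimethyl-1,3-dioxolan-4-yl for 2,2-dimethyl-1,3-dioxolan-4-yl on a saturated chain carbon bound to an aromatic nitrogen gives a 4.2-fold lower number from compound 3 to compound 4 (0.62 log units; beyond the scatter) and is the first step at this position to pass beyond the scatter. The position therefore does respond to the side chain, and compound 4 also separates from the two hydroxylated chains, with a 4.1-fold lower number from compound 2 to compound 4 (0.61 log units; beyond the scatter) and a 2.3-fold lower number from compound 1 to compound 4 (0.37 log units; beyond the scatter) as the remaining steps. Nothing available here explains this shift.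

The compounds shown leave open whether an amine, a carboxylic acid or a longer alkyl chain on this carbon would keep the lower number. They also leave open whether the two mirror-image forms of the 2,2-dimethyl-1,3-dioxolan-4-yl group would give the same value.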